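Methoxy on compound 2: expected step

This account rests on a few compounds, and the source may have more. Where it says the series, first, only, none or still open, it means among the compounds named here.

In an ADME assay on BaF3 cells (Mus musculus) for antiproliferative activity, read by a luciferase reporter, with a stated time of 3 days (a higher number here means a weaker inhibitor, a lower number a stronger inhibitor), compound 1 (`Cc1cc(Nc2nc(Nc3ccccc3S(=O)(=O)C(C)C)c3c(N)n[nH]c3n2)c(OC(C)C)cc1C1CCN(C)CC1`) gives 4500 nM. Compound 2 (`Cc1cc(Nc2nc(Nc3ccccc3S(=O)(=O)C(C)C)c3ccccc3n2)c(OC(C)C)cc1C1CCN(C)CC1`) gives 3240 nM, which lies within the scatter of the value for compound 1. Compound 3 (`COc1ccc2nc(Nc3cc(C)c(C4CCN(C)CC4)cc3OC(C)C)nc(Nc3ccccc3S(=O)(=O)C(C)C)c2c1`) carries methoxy in place of hydrogen on an aromatic carbon of a six-membered aromatic ring of carbon only: methoxy in place of hydrogen on an aromatic carbon. Among the compounds with values here, no measured pair isolates this change, so no step beyond the scatter is expected in this assay, in either direction. The expected change is a 1.1-fold lower number from compound 2 to compound 3 (0.03 log units; within the scatter). For compound 3 the estimated value is 3000 nM, with an expected range of 1000 nM to 9000 nM.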

Compound 3, half-maximal inhibitory concentration: 3940 nM
Estimate against measurement, compound 3: 1.3-fold (0.12 log units) below, within the range that was stated.
By their numbers in this assay, from the lowest: compounds 2, 3 and 1 (each within the scatter of the next).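

In this assay methoxy in place of hydrogen on an aromatic carbon, meta to a fused ring and para to a fused ring, gives a 1.2-fold higher number from compound 2 to compound 3 (0.08 log units; within the scatter) and so leaves the read-out unresolved from that of the unsubstituted parent at this position. Within the data shown here, this is the first single-place change that can be read as a step, and it shows that this carbon accepts methoxy without a shift beyond the scatter. Nothing available gives a reason for this result.

On these data alone, whether an amine, a carboxylic acid or a longer chain such as ethoxy on this same carbon would move the number beyond the scatter remains open. So does whether methoxy on the other carbons of this ring would behave alike.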